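Thiophene substituent and tolerance on kidney cells

The compounds below may be only part of what the source reports. "The series", "measured", "known", "first", "only" and "open" are said of these compounds alone.

Measured compounds:
- compound 1, `CCc1ccsc1CN[C@@H]1C[C@H]2C[C@@H]([C@H]1C)C2(C)C`, in an ADME assay on MDCK cells (Canis lupus familiaris) for cytotoxicity, read by microscopy, with a stated time of 48 h (a lower number here means that less compound is tolerated, a higher number that more compound is tolerated), compound 1 gives 25000 nM
- compound 2, `C[C@H]1[C@H](NCc2ccoc2)C[C@H]2C[C@@H]1C2(C)C`, compound 2 gives > 100000 nM
- compound 3, `C[C@H]1[C@H](NCc2cc(C3CCCCC3)cs2)C[C@H]2C[C@@H]1C2(C)C`, compound 3 gives 780 nM

The three share a bicyclic amine core and differ in the aromatic ring attached through the methylene and in the group on that ring. For compound 2 the result in this assay is a limit of the assay and not a number. Among the two numbers, compound 1 stands highest, so more of it is tolerated; compound 3 sits well below it, beyond the scatter, and carries a cyclohexyl on its thiophene where compound 1 carries an ethyl.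

Compound 4, `C[C@H]1[C@H](NCc2sccc2-c2ccsc2)C[C@H]2C[C@@H]1C2(C)C`, has not yet been measured in this assay. Compared with compound 1 the change is thiophen-3-yl in place of ethyl on an aromatic carbon. A larger ring group thus replaces a small chain on the thiophene. Since compound 3, the only other thiophene here bearing a large ring group, gives 780 nM, a lower number is expected for compound 4, with a step of an 8.3-fold lower number from compound 1 to compound 4 (0.92 log units; beyond the scatter) expected to lie beyond the scatter. Compound 4 is expected to give 3000 nM in this assay, in a range from 700 nM to 12000 nM.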

Compound 4, minimum cytotoxic concentration: 12500 nM
Compound 4: middle estimate off by 4.2-fold (0.62 log units), on the low side, and the stated range ends below it.
By their numbers in this assay, from the lowest: compound 3; then compounds 4 and 1 (each within the scatter of the next). At a limit, above all of these: compound 2.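

In this assay, among these compounds, the position on the thiophene two ring bonds from the ring sulfur now has its first comparison in which only one place changes, and thiophen-3-yl in place of ethyl gives a 2.0-fold lower number from compound 1 to compound 4 (0.30 log units; within the scatter). Among the compounds shown here, at this position an aromatic ring can therefore replace the small chain without a change that stands out from the scatter, something the earlier compounds could not show, since none of them differed from another in one place only; compound 3, at 780 nM, is linked to compound 1 by no single step, so its value cannot be assigned to ring size alone. Nothing shown gives a cause for the step from ethyl to thiophen-3-yl.

Going by these compounds, what remains open is how a cyclohexyl, or a group carrying an amine or a carboxylic acid, would read at this same position. Also open, on these data alone, is whether the result for thiophen-3-yl extends to other aromatic rings there, such as phenyl or pyridine.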